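The compounds below may be only part of what the source reports. "The series", "measured", "known", "first", "only" and "open" are said of these compounds alone.

Compound 1 `O=C1C[C@H](NC(=O)[C@@H]2COC[C@@H]3C/C=C\C[C@H](NC(=O)c4ccc(C(F)(F)F)cc4)C(=O)N32)C(O)O1` gives 6450 nM in an assay on isolated protein for inhibition of Caspase-8 (Homo sapiens); a higher number here means a weaker inhibitor, a lower number a stronger inhibitor. Among the compounds with values here, compound 2 `O=C1C[C@H](NC(=O)[C@@H]2COC[C@@H]3C/C=C\C[C@H](NC(=O)c4ccccc4C(F)(F)F)C(=O)N32)C(O)O1` gives 670 nM in this assay and stands lowest of the two numbers so far; its sole measured neighbour lies a full step away, a 9.6-fold lower number from compound 1 to compound 2 (0.98 log units; beyond the scatter). Compound 3 `O=C1C[C@H](NC(=O)[C@@H]2COC[C@@H]3C/C=C\C[C@H](NC(=O)c4ccccc4)C(=O)N32)C(O)O1` differs from compound 2 by hydrogen in place of trifluoromethyl on an aromatic carbon. Within the data shown here, no measured step removes a trifluoromethyl outright; the one step available, a 9.6-fold lower number from compound 1 to compound 2 (0.98 log units; beyond the scatter), merely moves that group from one aromatic carbon to another within the same ring, so it bears on the present change only loosely. It does show that the placement of this group matters to this assay, which makes its complete removal unlikely to pass unnoticed. The expectation for compound 3 is therefore a step of a 2.7-fold higher number from compound 2 to compound 3 (0.43 log units; beyond the scatter) toward a higher number, with wide uncertainty either way. The estimate for compound 3 in this assay is 1800 nM, within the range 450 nM to 7000 nM.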

Compound 3, half-maximal inhibitory concentration: 7900 nM
Compound 3: middle estimate off by 4.4-fold (0.64 log units), on the low side, outside the stated range (above it).
By their numbers in this assay, from the lowest: compound 2; then compounds 1 and 3 (each within the scatter of the next).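

In this assay the trifluoromethyl group counts only at one of its two placements: removing it from the 2-(trifluoromethyl)phenyl group gives a 12-fold higher number from compound 2 to compound 3 (1.07 log units; beyond the scatter) and so takes away about as much as the earlier move of the group gave, a 9.6-fold lower number from compound 1 to compound 2 (0.98 log units; beyond the scatter) in the other direction. Removing it from the 4-(trifluoromethyl)phenyl group gives a 1.2-fold higher number from compound 1 to compound 3 (0.09 log units; within the scatter) and leaves compound 1 and compound 3 indistinguishable, so the plain benzoyl compound serves as the reference level and only compound 2 stands apart from it. No measurement available here accounts for this difference between the two placements.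

Open, from the compounds shown here alone, is whether a chlorine atom, a methyl group or a methoxy group on the same aromatic carbon would hold the number of compound 2 or whether only trifluoromethyl does so. Also open, going by these compounds, is whether a second substituent on the ring would add to that step.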